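Trimming the Group on the Carbonyl Carbon

The source may report more compounds than this note shows. Statements on the series, on what has been measured and on what is new or still open speak of the compounds shown alone.

Of the compounds shown here, three sharing one core have been measured in an ADME assay on BHK15 cells (Mesocricetus auratus) for inhibition, read by XTT assay, with a stated time of 36 h; a lower number here means a stronger inhibitor of growth, a higher number a weaker inhibitor of growth. Compound 2 `CN(C)C(=O)c1sc(-c2ccc(Cl)cc2)nc1C(Br)Br` gives 163000 nM, the second highest of the three numbers. Compound 1 `CONC(=O)c1sc(-c2ccc(Cl)cc2)nc1C(Br)Br` gives 81400 nM, and compound 3 `CC(C)OC(=O)c1sc(-c2ccc(Cl)cc2)nc1C(Br)Br` gives 372000 nM. The change to compound 4 `CC(=O)c1sc(-c2ccc(Cl)cc2)nc1C(Br)Br` is methyl in place of dimethylamino on a carbonyl carbon. The measured steps at the same carbonyl carbon were a 2.0-fold higher number from compound 1 to compound 2 (0.30 log units; within the scatter), a 4.6-fold higher number from compound 1 to compound 3 (0.66 log units; beyond the scatter) and a 2.3-fold higher number from compound 2 to compound 3 (0.36 log units; beyond the scatter), so exchanging this group has so far moved the number only by modest amounts. None of these steps exchanges dimethylamino for methyl, so the direction is uncertain; a step of a 1.3-fold higher number from compound 2 to compound 4 (0.13 log units; within the scatter) is expected, toward a higher number and close to the scatter. Compound 4 is estimated at 220000 nM, between 80000 nM and 600000 nM.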

Compound 4, concentration for 50% growth inhibition: 83500 nM
Beside the measured number, compound 4's estimate is 2.6-fold (0.42 log units) above it; measured number inside the range.
By their numbers in this assay, from the lowest: compounds 1, 4 and 2 (each within the scatter of the next); then compound 3.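

Methyl on the carbonyl carbon, a single carbon in place of the larger groups, still gives a number level with the two lowest compounds (a 2.0-fold lower number from compound 2 to compound 4 (0.29 log units; within the scatter); a 1.0-fold higher number from compound 1 to compound 4 (0.01 log units; within the scatter)), so no nitrogen on this carbon is needed to stay at this level. Compound 3, with isopropoxy, remains the one that stands apart (a 4.5-fold lower number from compound 3 to compound 4 (0.65 log units; beyond the scatter)). No measured evidence accounts for this difference. Open, going by these compounds, is how a longer chain such as ethyl, or a hydroxy group that would make a carboxylic acid, would behave on this carbonyl carbon.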